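Swapping the aryl group on a shared core

A few compounds are considered here, and "the series" means these few. Any claim that something is new, unique, unknown or untested is made for them only; others in the source may bear on it.

Of the compounds shown here, three built on one shared core have been tested in an ADME assay on Vero cells (Chlorocebus sabaeus) for cytotoxicity, read by neutral red uptake, tested at 3150 ug/mL; a higher number here means a weaker effect of the compound at the concentration tested, a lower number a stronger effect. Compound 1 `O=C1CSC(c2cccc(O)c2)N1CCN1CCCCC1` gives 11%. Compound 2 `COc1ccccc1C1SCC(=O)N1CCN1CCCCC1` gives 5%, and compound 3 `O=C1CSC(c2cccc(F)c2)N1CCN1CCCCC1` gives 13%. Compound 1 thus stands second highest of the three numbers, with compound 3 nearest and compound 2 furthest, both gaps within the scatter. Within the data shown here, the only measured step that changes one place is a number 2 percentage points higher from compound 1 to compound 3 (within the scatter), and it bears on the new compound only loosely, as it also exchanges one substituent of the aromatic ring for another.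

Compound 4 `O=C1CSC(c2ccccc2Cl)N1CCN1CCCCC1` differs from compound 1 by 2-chlorophenyl in place of 3-hydroxyphenyl on a saturated ring carbon. Compound 2 shows that an aromatic ring without a hydroxy group still gives a low number, so no step beyond the scatter is expected in this assay. The step is expected to be a number 1 percentage points lower from compound 1 to compound 4 (within the scatter). Compound 4 is therefore estimated at 10%, most likely between 2% and 20%.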

Compound 4, a percentage reported as activity, at one concentration (the size of the read-out at that concentration, not a potency): 22%
Compound 4: middle estimate off by 12 percentage points, on the low side, and the stated range ends below it.
By their numbers in this assay, from the lowest: compounds 2, 1, 3 and 4 (each within the scatter of the next, the first and the last beyond it).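

In this assay, 2-chlorophenyl in place of 3-hydroxyphenyl on the saturated ring carbon gives a step beyond the scatter (a number 11 percentage points higher from compound 1 to compound 4 (beyond the scatter)), and so does chloro in place of methoxy on an aromatic carbon (a number 17 percentage points higher from compound 2 to compound 4 (beyond the scatter)), so changing the aryl group at this position can shift the number measurably, which the earlier step did not show. The change from 3-fluorophenyl to 2-chlorophenyl stays within the scatter (a number 9 percentage points higher from compound 3 to compound 4 (within the scatter)), so compound 3 and compound 4 cannot be told apart here. Nothing measured explains these steps.

Compound 4 changes both the substituent and its place on the ring, so the two effects remain tangled. A 3-chlorophenyl or 2-fluorophenyl group on the same carbon could separate them, while an aryl group carrying an amine or a carboxylic acid would test a wider range of substituents.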